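Swapping Methoxy for Bromo on the Shared Core

A few compounds are considered here, and "the series" means these few. Any claim that something is new, unique, unknown or untested is made for them only; others in the source may bear on it.

compound 1 `COc1cccc2c(=O)c(-c3nn[nH]n3)c[nH]c12`: 0.312 mg/kg
compound 2 `O=c1c(-c2nn[nH]n2)c[nH]c2c(Cl)c(Cl)ccc12`: > 10 mg/kg
compound 3 `COc1ccc(OC)c2c(=O)c(-c3nn[nH]n3)c[nH]c12`: > 10 mg/kg

For the measured compounds named here, in a functional assay on the whole organism (strain Sprague-Dawley) for inhibition, with Rattus norvegicus as the target (on this read-out lower numbers stand for an effect already at smaller amounts and higher numbers for an effect only at larger amounts of compound), compound 1 gives 0.312 mg/kg, the only true number among the three measured compounds. Compound 2 reaches only a limit of the assay, > 10 mg/kg. Compound 3 likewise stops at a limit, > 10 mg/kg, namely (the limit of > 10 mg/kg in this assay, at which 2 of the 3 values shown sit). Going by the values given here, the single measured step, an at least 32-fold higher number from compound 1 to compound 3 (1.50 log units; beyond the scatter), shows how sharply one added group can weaken the effect. Compound 4 `O=c1c(-c2nn[nH]n2)c[nH]c2c(Br)cccc12` differs from compound 1 by bromo in place of methoxy on an aromatic carbon. Among the compounds with values here, no measured step covers this exchange, so the expectation rests loosely on compound 1 alone and on the tendency of changes at this core to weaken the effect. Compound 4 is expected to show a 9.6-fold higher number from compound 1 to compound 4 (0.98 log units; beyond the scatter), landing at an estimated 3 mg/kg with a range from 0.5 mg/kg to 10 mg/kg.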

Compound 4, minimum effective dose: > 10 mg/kg
Compound 4: only a limit was reported (the forecaster's own chance of this, stated with the estimate: 40%); middle value at least 3.3-fold (0.52 log units) away from the limit.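

In this assay, bromo in place of methoxy on this aromatic carbon gives an at least 32-fold higher number from compound 1 to compound 4 (1.50 log units; beyond the scatter). The earlier step added a second methoxy and kept this one, whereas this step exchanges the methoxy itself, so among the compounds shown, the effect is lost when that group goes. Compound 4 also stops at a limit, so the full size of the loss cannot be read: the limit of > 10 mg/kg in this assay, at which 3 of the 4 values shown sit.

As far as these compounds go, what stays open is whether any other group at this place keeps the effect. An ethoxy, a hydroxy or an amine could each test this.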